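The source may hold more compounds than are shown below. What is called first, only, known or untested is meant among the compounds shown, and "the series" means these compounds.

Compound 3 `O=C(/C(=C/c1ccc(Cl)cc1)Cc1ccc(Cl)cc1)c1ccc(Cl)cc1Cl` is the strongest growth inhibitor among the three measured compounds in a functional assay on DU-145 cells (Homo sapiens) for inhibition, read by trypan blue exclusion, with a stated time of 96 h; a higher number here means a weaker inhibitor of growth, a lower number a stronger inhibitor of growth: compound 3 gives 10000 nM. Compound 1 `Cc1ccc(/C=C(/SCc2ccc(Cl)cc2Cl)C(=O)c2ccc(Cl)cc2)s1` gives 50000 nM, and compound 2 `Cc1ccc(/C=C(/SCc2ccc(Cl)cc2)C(=O)c2ccc(Cl)cc2)s1` gives 50000 nM. Compound 1 and compound 2 share one core, while compound 3 is built on another; the difference between the two cores is not broken down here.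

Compound 4 `O=C(/C(=C/c1ccc(Cl)cc1)Cc1ccc(Cl)c(Cl)c1)c1ccc(Cl)cc1Cl` has not yet been measured. It differs from compound 3 by chloro in place of hydrogen on an aromatic carbon. The same kind of change, (chloro in place of hydrogen on an aromatic carbon), turns compound 2 into compound 1, although the surroundings of the place differ: in compound 1 the entering chloro group is ortho to a large group and meta to a chloro group, whereas in compound 4 it is ortho to a chloro group and meta to a large group. The earlier step, no change at the digits printed from compound 2 to compound 1 (within the scatter), stayed within the scatter. Resting on that earlier step, only a small step is expected, no change at the digits printed from compound 3 to compound 4 (within the scatter), in this assay. Compound 4 is therefore estimated at 10000 nM, with a likely range from 4000 nM to 25000 nM.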

Compound 4, concentration for 50% growth inhibition: 1000 nM
Beside the measured number, compound 4's estimate is 10-fold (1.00 log units) above it, outside the stated range (below it).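

In this assay, turning the 4-chlorobenzyl group into the 3,4-dichlorobenzyl group gives a 10-fold lower number from compound 3 to compound 4 (1.00 log units; beyond the scatter). Among the compounds shown here, the same kind of change therefore behaved differently on the two cores: the same change on two cores in this assay, no change at the digits printed (within the scatter) from compound 2 to compound 1 and a 10-fold lower number (1.00 log units; beyond the scatter) from compound 3 to compound 4, 10-fold (1.00 log units) apart, beyond the scatter of two such steps This shows that a result for adding a chloro group on one core cannot simply be carried over to the other, but it does not show what drives the difference, as the two steps differ both in their core and in where the chloro group enters, and each core offers only one pair.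

The compounds shown leave open whether a chloro group entering at this same place on the core of compound 2 would give a step like the one seen on the core of compound 3. They also leave open whether the step is specific to chloro, or whether a methyl group, a methoxy group or an amine at this place would give a similar one.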